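From 3,4-Dimethoxyphenyl to 2-Methoxyphenyl on a Second Core

A few compounds are considered here, and "the series" means these few. Any claim that something is new, unique, unknown or untested is made for them only; others in the source may bear on it.

In a functional assay on NCI-H1299 cells (Homo sapiens) for antiproliferative activity, read by fluorescence and resazurin assay, with a stated time of 48 h (on this read-out higher numbers stand for weaker inhibition and lower numbers for stronger inhibition), three compounds have been measured so far:
Compound 1, `COc1ccccc1Cn1cc(-c2ccc(O)cc2)c(-c2ccc(O)cc2)c1`, gives 23100 nM.
Compound 2, `COc1ccc(Cn2cc(-c3ccc(O)cc3)c(-c3ccc(O)cc3)c2)cc1OC`, gives 29200 nM.
Compound 3, `COc1ccc(Cn2cc(-c3ccc(O)c(O)c3)c(-c3ccc(O)c(O)c3)c2)cc1OC`, gives 10500 nM.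

Compound 2 and compound 1 share one core and differ in a single place: 2-methoxyphenyl in place of 3,4-dimethoxyphenyl on a saturated chain carbon bound to an aromatic nitrogen. That change made a 1.3-fold lower number from compound 2 to compound 1 (0.10 log units; within the scatter). Compound 3 sits on a second core; the difference between the two cores is not broken down here. Compound 3 has the lowest number of the three, and its steps to both other compounds lie beyond the scatter.

Compound 4, `COc1ccccc1Cn1cc(-c2ccc(O)c(O)c2)c(-c2ccc(O)c(O)c2)c1`, is not yet measured. It repeats the same change on the core of compound 3: 2-methoxyphenyl in place of 3,4-dimethoxyphenyl on a saturated chain carbon bound to an aromatic nitrogen. The step is expected to be small, a 1.3-fold lower number from compound 3 to compound 4 (0.12 log units; within the scatter), because the earlier change made a 1.3-fold lower number from compound 2 to compound 1 (0.10 log units; within the scatter). Compound 4 is therefore estimated at 8000 nM, with most repeat measurements expected between 4000 nM and 16000 nM.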

Compound 4, half-maximal inhibitory concentration: 8600 nM
For compound 4 the middle estimate is 1.1-fold (0.03 log units) below the measured one, within the range that was stated.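

In this assay, putting 2-methoxyphenyl in place of 3,4-dimethoxyphenyl on the second core gives a 1.2-fold lower number from compound 3 to compound 4 (0.09 log units; within the scatter). Set beside the earlier step on the first core, the two results agree: the same change on two cores in this assay, a 1.3-fold lower number (0.10 log units; within the scatter) from compound 2 to compound 1 and a 1.2-fold lower number (0.09 log units; within the scatter) from compound 3 to compound 4, 1.0-fold (0.02 log units) apart, within the scatter of two such steps. This shows that, on these two cores, the change carries over as a small step, but it does not show that either group is better than the other or that the step would stay this small on a third core.

The compounds shown leave open what a group of a different kind, such as an amine, a carboxylic acid or a longer chain, would do on the saturated chain carbon bound to the aromatic nitrogen. On these data alone, whether any such group would give a step beyond the scatter remains unknown.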